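Compound 3 to compound 4: changing the aryl group

This account rests on a few compounds, and the source may have more. Where it says the series, first, only, none or still open, it means among the compounds named here.

Going by the values given here, in a functional assay on HOS-TE85 cells (Homo sapiens) for inhibition, read by CCK-8 assay, with a stated time of 72 h (a higher number here means a weaker inhibitor, a lower number a stronger inhibitor), compound 3 `COc1ccc(F)cc1N1C(=O)CSC1c1cccc(C(=O)NCCCCc2ccccc2)c1` gives 8.8 nM, the only number so far. Compound 1 `O=C(NCCCCc1ccccc1)c1cccc(C2SCC(=O)N2c2cnccn2)c1` reads > 1000 nM, which is a limit. Compound 2 `CCN(CC)c1ccc(N2C(=O)CSC2c2cccc(C(=O)NCCCCc3ccccc3)c2)cc1` reads > 1000 nM, also a limit.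

Compound 4 `Cc1cccc(N2C(=O)CSC2c2cccc(C(=O)NCCCCc3ccccc3)c2)c1` carries a single change, 3-methylphenyl in place of 5-fluoro-2-methoxyphenyl on an amide-type nitrogen in a ring. Two measured steps changed the group at this place, and both were large: an at least 110-fold lower number from compound 1 to compound 3 (2.05 log units; beyond the scatter), and an at least 110-fold lower number from compound 2 to compound 3 (2.05 log units; beyond the scatter). Neither involves 3-methylphenyl, so they show only that this place can move the read-out strongly. A move to a higher number is therefore expected in this assay, with the expected step being a 6.8-fold higher number from compound 3 to compound 4 (0.83 log units; beyond the scatter). The estimate for compound 4 is 60 nM, with an expected range of 8 nM to 500 nM.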

Compound 4, half-maximal inhibitory concentration: 93.2 nM
Compound 4: the middle estimate sits 1.6-fold (0.19 log units) below what was measured, and the stated range covers the measured number.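

In this assay, going by these compounds alone, the change gives an 11-fold higher number from compound 3 to compound 4 (1.02 log units; beyond the scatter) as the first step at this position with a number at both ends, so 5-fluoro-2-methoxyphenyl and 3-methylphenyl can be ranked by size of step. The steps of an at least 10-fold lower number from compound 2 to compound 4 (1.03 log units; beyond the scatter) and an at least 10-fold lower number from compound 1 to compound 4 (1.03 log units; beyond the scatter) place 3-methylphenyl clear of the two weak groups. Those two steps remain bounds: the limit of > 1000 nM in this assay, at which 2 of the 4 values shown sit.

Whether the methoxy or the fluorine of compound 3 accounts for its lower number stays open. So does the effect of a plain phenyl or a carboxylic acid at this place.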